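The source may report more compounds than this note shows. Statements on the series, on what has been measured and on what is new or still open speak of the compounds shown alone.

Measured compounds:
compound 1 `CCn1nnc(-c2sc(-c3cccc(OC)c3)nc2O)n1` gives 245 nM in an assay on HEK293 cells for inhibition of transient receptor potential cation channel subfamily M member 8 (Homo sapiens), read by FLIPR, with stated times of 5 min and 3 min; on this read-out lower numbers stand for stronger inhibition and higher numbers for weaker inhibition
compound 2 `CCn1nnc(-c2sc(-c3ccccc3OC)nc2O)n1` gives 2790 nM in this assay
compound 3 `CCn1nnc(-c2sc(-c3cccc(C)c3)nc2O)n1` gives 369 nM in this assay

Compound 1 and compound 2 share the same atoms joined differently; the difference between the two cores is not broken down here. Compound 2 gives the highest number of the three, a gap beyond the scatter from both compound 3 and compound 1.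

One change has been measured once: methyl in place of methoxy on an aromatic carbon. The step it made was a 1.5-fold higher number from compound 1 to compound 3 (0.18 log units; within the scatter), which lies within the scatter, so the two values of compound 1 and compound 3 are not ordered by this read-out.

Compound 4 `CCn1nnc(-c2sc(-c3ccccc3C)nc2O)n1` is not yet measured. It relates to compound 2 by the same kind of change: methyl in place of methoxy on an aromatic carbon. The place differs in its surroundings: here the group sits ortho to a large group, whereas from compound 1 to compound 3 it sits meta to a large group. Within the data shown here, only the step from compound 1 to compound 3 is available as a guide.

The expected step in this assay is a 1.3-fold higher number from compound 2 to compound 4 (0.10 log units; within the scatter), resting on the step from compound 1 to compound 3 being a 1.5-fold higher number from compound 1 to compound 3 (0.18 log units; within the scatter), and allowing a wider range because the surroundings of the place are not the same. Compound 4 is estimated at 3500 nM, with a range from 1200 nM to 10000 nM.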

Compound 4, half-maximal inhibitory concentration: 60 nM
The estimate for compound 4 lay 58-fold (1.77 log units) above the measured number; the measured number lies below the stated range.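

In this assay, methyl in place of methoxy on an aromatic carbon, with the group ortho to a large group, gives a 47-fold lower number from compound 2 to compound 4 (1.67 log units; beyond the scatter), a large step beyond the scatter. The same change therefore does not carry over as a single step between the two cores: the same change on two cores in this assay, a 1.5-fold higher number (0.18 log units; within the scatter) from compound 1 to compound 3 and a 47-fold lower number (1.67 log units; beyond the scatter) from compound 2 to compound 4, 70-fold (1.85 log units) apart, beyond the scatter of two such steps

For this series, a step measured at one place on the ring is no safe guide to the same change at another place. These two steps do not show what sets them apart: they give no measured property of methoxy or methyl, and two pairs cannot establish a rule for every place on the ring.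

The compounds shown leave open whether other groups ortho to a large group, such as chlorine, ethyl or ethoxy, would fall near compound 4 or near compound 2. They also leave open whether the step from methoxy to methyl would hold if the ethyl chain on the shared core gave way to a longer chain or an amine.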